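The compounds below may be only part of what the source reports. "The series", "measured", "known", "first", "only" and "open" are said of these compounds alone.

Measured compounds:
compound 1 `O=C1NCCc2nc(C#Cc3ccccc3)sc21` — > 10000 nM
compound 2 `Cc1cccc(C#Cc2nc3c(s2)C(=O)NCC3)c1` — > 10000 nM
compound 3 `CCN1CCc2nc(C#Cc3ccccc3)sc2C1` — 1200 nM

In an assay on HEK293 cells for negative allosteric modulation of metabotropic glutamate receptor 5 (Homo sapiens), read by FLIPR, with a stated time of 1 h (a lower number here means a stronger inhibitor, a higher number a weaker inhibitor), compound 1 reports a limit, > 10000 nM, not a number. Compound 2 likewise reports only a limit, > 10000 nM. For the measured compounds named here, the one step between measured compounds, methyl in place of hydrogen on an aromatic carbon, is a step that the two limits leave unreadable from compound 1 to compound 2; both ends sit at the limit of > 10000 nM in this assay, at which 2 of the 3 values shown sit, so it gives no usable size. Going by the values given here, compound 3 is the only compound of the three with a number in this assay, 1200 nM, and so is the reference point for the series.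

Compound 4 `CC1CC(C(=O)N2CCc3nc(C#Cc4ccccc4)sc3C2)C1` is not yet measured. It differs from compound 3 by (3-methylcyclobutyl)carbonyl in place of ethyl on an amine nitrogen in a ring. No measured step touches the amine nitrogen in the ring, so none of the steps shown bears on this change; the only step shown lies on an aromatic carbon and is unreadable. Among the compounds with values here, the expectation for the step from compound 3 to compound 4 in this assay therefore rests on no precedent, and the estimated step is a 1.7-fold lower number from compound 3 to compound 4 (0.23 log units; within the scatter), with no direction claimed beyond the scatter. Compound 4 is expected to give about 700 nM in this assay, within a wide range from 100 nM to 5000 nM.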

Compound 4, half-maximal inhibitory concentration: > 10000 nM
Compound 4 gave a limit, no number (the forecaster's own chance of this, stated with the estimate: 15%); middle value at least 14-fold (1.15 log units) from the limit.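

In this assay compound 4 gives > 10000 nM as a limit of the assay, not a number. For the compounds shown here, on the amine nitrogen in a ring, (3-methylcyclobutyl)carbonyl in place of ethyl gives an at least 8.3-fold higher number from compound 3 to compound 4 (0.92 log units; beyond the scatter) as the first readable step at this position, and the true size may be larger because only a floor is available. Going by these compounds alone, this position is therefore sensitive to the substituent, at least for this one change, and compound 3 remains the only compound with a number.

The compounds shown do not separate the contribution of the carbonyl from that of the four-membered ring, and the step on the aromatic carbon from compound 1 to compound 2 cannot be read. As far as these compounds go, what a methyl, a longer alkyl chain or a benzyl group on this nitrogen would give remains open.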